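The source may report more compounds than this note shows. Statements on the series, on what has been measured and on what is new or still open speak of the compounds shown alone.

Measured compounds:
- Compound 1, `Nc1nc2ccccn2c1-c1ccc(O)cc1`: in an assay on isolated protein for inhibition of ubiquitin carboxyl-terminal hydrolase 14 (Homo sapiens) (on this read-out lower numbers stand for stronger inhibition and higher numbers for weaker inhibition), compound 1 gives > 100000 nM, which is a limit of the assay and not a number.
- Compound 2, `CNc1nc2ccccn2c1-c1ccc(O)cc1`: in this assay compound 2 gives > 100000 nM, likewise a limit.
- Compound 3, `CC(C)Nc1nc2ccccn2c1-c1ccc(O)cc1`: in this assay compound 3 gives > 100000 nM, again a limit.

Compound 1 therefore stands only at a limit of the assay, without a measured number. All three shown values sit at the same limit, as the limit of > 100000 nM in this assay, at which 3 of the 3 values shown sit, records. The steps among them, a step that the two limits leave unreadable from compound 1 to compound 2, a step that the two limits leave unreadable from compound 1 to compound 3 and a step that the two limits leave unreadable from compound 2 to compound 3, cannot be read in size or direction: both ends of each sit at the limit. Compound 4, `Nc1nc2cc(C(F)(F)F)ccn2c1-c1ccc(O)cc1`, is still to be measured and differs from compound 1 by trifluoromethyl in place of hydrogen on an aromatic carbon. Among the measured compounds shown here, none of the measured steps touches this position, and none of them is readable. Nothing among the shown compounds therefore points to a step beyond the scatter in either direction. The estimate for compound 4 in this assay is 100000 nM, with a range from 30000 nM to 300000 nM, and the expected step is a number no higher from compound 1 to compound 4 (the limit leaves the size open), most likely ending once more at a limit rather than a number.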

Compound 4, half-maximal inhibitory concentration: > 100000 nM
Compound 4: no number, only a limit (the forecaster's own chance of this, stated with the estimate: 80%); the middle value lies on the limit itself.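

In this assay, compound 1 and compound 4 both sit at a limit and not at a number, so the step between them cannot be read in size or direction: the limit of > 100000 nM in this assay, at which 4 of the 4 values shown sit.

The compounds shown leave open whether any change to the shared core gives a measurable number in this assay.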